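This account rests on a few compounds, and the source may have more. Where it says the series, first, only, none or still open, it means among the compounds named here.

Of the compounds shown here, three built on a shared core have been tested in a functional assay on MDA-MB-468 cells (Homo sapiens) for inhibition, read by sulforhodamine B assay, with a stated time of 48 h; on this read-out higher numbers stand for weaker inhibition of growth and lower numbers for stronger inhibition of growth. Compound 1 `COc1cc(-c2cc(/C=C/C(=O)c3ccc(N)cc3)[nH]n2)cc(OC)c1OC` gives 2910 nM in this assay. Compound 2 `COc1ccc(-c2cc(/C=C/C(=O)c3ccc(OC)c(OC)c3)[nH]n2)cc1` gives 2940 nM, and compound 3 `COc1ccc(-c2cc(/C=C/C(=O)c3cc(OC)c(OC)c(OC)c3)[nH]n2)cc1OC` gives 3270 nM. Compound 1 therefore sits alongside compound 2 and compound 3: the gaps between the three numbers all fall within the usual scatter of repeated measurements of this kind, so none of the three can be set apart from the others on these readings.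

Compound 4 `COc1cc(-c2cc(/C=C/C(=O)c3ccc(F)c(F)c3)[nH]n2)cc(OC)c1OC` has not yet been measured in this assay. It differs from compound 1 in one place: 3,4-difluorophenyl in place of 4-aminophenyl on a carbonyl carbon. For the measured compounds named here, no measured pair of compounds shows a change of this kind, so there is no earlier step to lean on. The expected step is a modest one, a 1.2-fold higher number from compound 1 to compound 4 (0.08 log units; within the scatter), and it may well stay within the scatter. On that basis compound 4 is estimated to give 3500 nM in this assay, within a range from 1500 nM to 9000 nM.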

Compound 4, concentration for total growth inhibition: 9470 nM
For compound 4 the middle estimate is 2.7-fold (0.43 log units) below the measured one; the measured number lies above the stated range.
By their numbers in this assay, from the lowest: compounds 1, 2 and 3 (each within the scatter of the next); then compound 4.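

In this assay, putting 3,4-difluorophenyl in place of 4-aminophenyl on a carbonyl carbon brings a 3.3-fold higher number from compound 1 to compound 4 (0.51 log units; beyond the scatter), which here means weaker inhibition of growth. For the compounds shown here, the three earlier compounds could not be set apart, and no two of them differed in just one place, so this is the first sign that the group at this position can move the read-out beyond the scatter. Nothing available explains why this change has that effect.

This single change removes the amino group and adds two fluorines at once, so the compounds shown leave open which of these matters more. A plain phenyl or a 4-hydroxyphenyl at the same place, on the core of compound 1, would help to separate the two.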